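Removing a Fluoro Group from a Quinazoline-Type Cytotoxic Series

This account rests on a few compounds, and the source may have more. Where it says the series, first, only, none or still open, it means among the compounds named here.

The study compared a small set of compounds in a functional assay on DU-145 cells (Homo sapiens) for cytotoxicity, read by MTT assay, with a stated time of 2 days, tested at 10 uM; a higher number here means more inhibition at the concentration tested (going by the name of the read-out), a lower number less inhibition. Compound 1, `Cc1cccc(N2CCN(CCCCNc3nc(NCc4ccco4)c4cc(F)ccc4n3)CC2)c1C`, gave 93.4% in this assay. Compound 2, `Cc1cccc(N2CCN(CCCCNc3nc(NCc4ccco4)c4ccccc4n3)CC2)c1C`, gave 93.6% in this assay. The two differ by hydrogen in place of fluoro on an aromatic carbon, and the step recorded was a number 0.2 percentage points higher from compound 1 to compound 2 (within the scatter). Compound 3, `CCN(CC)CCNc1nc(NCc2ccco2)c2cc(F)ccc2n1`, gave 26.6% in this assay, the lowest of the three numbers; the difference between its core and the core of compound 1 is not broken down here, since the two compounds differ in more than one place.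

Compound 4, `CCN(CC)CCNc1nc(NCc2ccco2)c2ccccc2n1`, had not yet been measured. It differs from compound 3 by hydrogen in place of fluoro on an aromatic carbon. Among the compounds with values here, this is the same change as the one between compound 1 and compound 2, at a place described in the same words. The expected step from compound 3 to compound 4 is a number 0.4 percentage points higher from compound 3 to compound 4 (within the scatter), which rests on the earlier pair, because a number 0.2 percentage points higher from compound 1 to compound 2 (within the scatter) lay within the scatter. For compound 4 in this assay the estimate is therefore 27%. Within the data shown here, the expected range for compound 4 runs from 12% to 45%, allowing for the ordinary scatter of the measurement and for the single precedent on which the expectation rests.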

Compound 4, a percentage reported as inhibition, at one concentration (the size of the read-out at that concentration, not a potency): 28.5%
The estimate for compound 4 lay 1.5 percentage points below the measured number, within the range that was stated.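

Putting hydrogen in place of fluoro on the aromatic carbon gave, in this assay, a number 1.9 percentage points higher from compound 3 to compound 4 (within the scatter), and the same change behaved alike on the two cores: the same change on two cores in this assay, a number 0.2 percentage points higher (within the scatter) from compound 1 to compound 2 and a number 1.9 percentage points higher (within the scatter) from compound 3 to compound 4, 1.7 percentage points apart, within the scatter of two such steps

Across these two pairs, then, the fluoro group could be removed without a step that stands out from the ordinary scatter of the measurement, and the earlier pair served as a fair guide to the later one. This does not show that the change would be equally silent on any other core in the series, since it rests on two pairs, one position, one cell line and a single tested concentration, and a read-out of this kind is not a potency.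

The compounds shown leave open whether another group on that same aromatic carbon, such as chloro, methoxy or nitrile, would read like fluoro and hydrogen or would move the number beyond the scatter. They also leave open whether the change would stay as quiet on a core whose side chain ends in a morpholine or a carboxylic acid rather than in the amines seen here.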